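The source may report more compounds than this note shows. Statements on the series, on what has been measured and on what is new or still open speak of the compounds shown alone.

Going by the values given here, in a functional assay on NIH3T3 cells (Mus musculus) (on this read-out lower numbers stand for an effect already at smaller amounts and higher numbers for an effect only at larger amounts of compound), compound 1 (`Cn1cncc1C(OCc1ccc(C#N)cc1/C=C/c1ccccn1)c1ccc(C#N)cc1`) gives 23.1 nM and compound 2 (`Cn1cncc1C(OCc1ccc(C#N)cc1C#CCCCCO)c1ccc(C#N)cc1`) gives 20.9 nM as the only two numbers so far, and they cannot be told apart. Compound 3 (`Cn1cncc1C(OCc1ccc(C#N)cc1-c1ccc(C#N)cc1)c1ccc(C#N)cc1`) keeps the shared core and changes one group (4-cyanophenyl in place of 6-hydroxyhex-1-yn-1-yl on an aromatic carbon) on the same aromatic carbon where compound 1 and compound 2 differ. Among the compounds with values here, the one measured step that bears on this is a 1.1-fold lower number from compound 1 to compound 2 (0.04 log units; within the scatter) (within the scatter), an exchange of one group for another at that carbon. That single step shows no clear shift in the number, but neither measured compound carries 4-cyanophenyl there, so the range must stay wide. In this assay no step beyond the scatter is therefore expected, and the estimated size is a 1.0-fold lower number from compound 2 to compound 3 (0.02 log units; within the scatter). The expected value for compound 3 is 20 nM, with an estimated range from 7 nM to 60 nM.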

Compound 3, half-maximal effective concentration: < 0.1 nM
Compound 3 gave a limit, no number; the forecaster's own chance of this, stated with the estimate: 3%; at least 200-fold (2.30 log units) between middle value and limit.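

In this assay compound 3 gives a limit of the assay, not a number: the limit of < 0.1 nM in this assay, at which 1 of the 3 values shown sits. This carbon, on the ring ortho to a large group and meta to a cyano group, turns out to be highly sensitive to what it carries: 4-cyanophenyl in place of 6-hydroxyhex-1-yn-1-yl gives an at least 200-fold lower number from compound 2 to compound 3 (2.32 log units; beyond the scatter), and 4-cyanophenyl in place of 2-(pyridin-2-yl)ethenyl gives an at least 230-fold lower number from compound 1 to compound 3 (2.36 log units; beyond the scatter). The earlier exchange at the same carbon gave only a 1.1-fold lower number from compound 1 to compound 2 (0.04 log units; within the scatter), so that pair alone showed no such sensitivity.

Going by these compounds, whether a plain phenyl group or a 4-aminophenyl group at this carbon would behave the same remains open, so the part played by the new ring cannot be separated from that of its nitrile. The limit also leaves the full size of both new steps unknown.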